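This account rests on a few compounds, and the source may have more. Where it says the series, first, only, none or still open, it means among the compounds named here.

Compound 1 `O=C(O)CNc1cccc(CNc2cc(C(F)(F)F)cc3[nH]ncc23)c1` is one of three compounds already tested in an assay for inhibition of Tryptophan 2,3-dioxygenase (Homo sapiens), with stated times of 10 min and 60 min; a higher number here means a weaker inhibitor, a lower number a stronger inhibitor. For compound 1 the result is a limit of the assay rather than a number, > 100000 nM. Compound 3 `O=C1NC(=O)c2c(NCc3ccccc3[N+](=O)[O-])cccc21`, built on a different core, also returns only a limit, > 100000 nM. So compound 1 stands at the limit of > 100000 nM in this assay, at which 2 of the 3 values shown sit, and in this assay it shows no measurable inhibition. For the measured compounds named here, the one compound that gives a number is compound 2 `O=[N+](O)c1c(Cl)cccc1CNc1cc(C(F)(F)F)cc2[nH]ncc12`, which in this assay reaches 170 nM.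

Compound 4 `FC(F)(F)c1cc(NCc2cccc(Br)c2)c2cn[nH]c2c1` has not yet been measured. It differs from compound 1 in one place: bromo in place of (carboxymethyl)amino on an aromatic carbon. The side chain carrying the acid is removed and a single bromine atom takes its place on the same ring carbon.

Going by the values given here, no measured pair here shows the effect of such a change, so the expectation rests on two observations. Compound 1 returns only a limit of the assay in this assay. Compound 2, a bromine-free relative of the same core, gives 170 nM. The step from compound 1 to compound 4 is expected to be an at least 20-fold lower number from compound 1 to compound 4 (1.30 log units; beyond the scatter), toward stronger inhibition. Compound 4 is therefore estimated at 5000 nM, somewhere between 500 nM and 100000 nM.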

Compound 4, half-maximal inhibitory concentration: 19100 nM
Compound 4: the middle estimate sits 3.8-fold (0.58 log units) below what was measured; measured number inside the range.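

In this assay, putting bromo in place of (carboxymethyl)amino on this aromatic carbon gives an at least 5.2-fold lower number from compound 1 to compound 4 (0.71 log units; beyond the scatter), the first step read at this position, and inhibition becomes measurable once the side chain carrying the acid is gone. On these data alone, the true size of the step remains unknown because compound 1 gives only a limit of the assay: the limit of > 100000 nM in this assay, at which 2 of the 4 values shown sit. This single change removes one group and adds another, so the gain cannot be divided between losing the side chain and gaining the bromine.

The compounds shown leave open what a methyl group, a methoxy group or a plain hydrogen would give on this same ring carbon. They also leave open whether a shorter chain ending in a carboxylic acid, or a longer chain without the acid, would keep or lose the inhibition seen with compound 4.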